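Fluoro on the benzyl ring of a proline amide

A few compounds are considered here, and "the series" means these few. Any claim that something is new, unique, unknown or untested is made for them only; others in the source may bear on it.

The series shares one core. Compound 1 `NC(=O)[C@@H]1CC[C@H](c2ccc(Oc3ccc(F)cc3)cc2)N1` carries a fluorinated phenoxy group and in an ADME assay on a cell-free system (plasma, Rattus norvegicus) for protein binding (a higher number here means a larger unbound share of the compound, a lower number a smaller unbound share), compound 1 gives 0.11. Compound 2 `NC(=O)[C@@H]1CC[C@H](c2ccc(OCc3ccccc3)cc2)N1` carries a benzyloxy group in place of the phenoxy group; in this assay compound 2 gives "not determined" (no result reported), so no number stands for it. Compound 3 `C[C@@H](Oc1ccc([C@H]2CC[C@@H](C(N)=O)N2)cc1)c1ccccc1` likewise has no number, as in this assay compound 3 gives "not determined" (no result reported). Among the compounds with values here, compound 2 therefore stands without a measured unbound fraction, and no step between measured compounds can be drawn from it.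

Compound 4 `NC(=O)[C@@H]1CC[C@H](c2ccc(OCc3cccc(F)c3)cc2)N1` is the next member. The difference from compound 2 is fluoro in place of hydrogen on an aromatic carbon. This is a single change at one aromatic carbon of the benzyl ring.

Within the data shown here, with no measured step to lean on, the step in this assay from compound 2 to compound 4 is expected to be small, no larger than the usual scatter, or at most a slight lowering of the unbound fraction. Among the measured compounds shown here, the only anchor is compound 1, which also carries a fluorine on its outer ring and gives 0.11. Compound 4 is therefore estimated to give 0.08 in this assay, with a range from 0.03 to 0.2.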

Compound 4, unbound fraction: 0.033
Compound 4: the middle estimate sits 2.4-fold (0.38 log units) above what was measured; measured number inside the range.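

Within the data shown here, compound 2 has no single number in this assay, and no step to compound 4 can be read from it. The compounds shown leave open how fluoro in place of hydrogen on the benzyl ring shifts the unbound fraction. Nothing in the data shown bears on the result for compound 4.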